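The compounds below may be only part of what the source reports. "The series", "measured", "known", "first", "only" and "open" are said of these compounds alone.

Measured in a functional assay on A549 cells (Homo sapiens) for cytotoxicity, read by sulforhodamine B assay, with a stated time of 72 h; on this read-out lower numbers stand for stronger inhibition and higher numbers for weaker inhibition:
Compound 1 `CCCC(=O)Nc1ccn([C@@H]2CO[C@H](CO)O2)c(=O)n1`: 6600 nM
Compound 2 `CCCCCCCCCCCCCCCCCC(=O)Nc1ccn([C@@H]2CO[C@H](CO)O2)c(=O)n1`: 25 nM

Compound 1 has the higher of the two numbers, so it is the weaker inhibitor. Compound 3 `O=C(Nc1ccn([C@@H]2CO[C@H](CO)O2)c(=O)n1)c1ccccc1` keeps the core of compound 1 and differs by phenyl in place of propyl on a carbonyl carbon. Within the data shown here, no measured pair shows this swap. The new group stays far closer in size to propyl than to the long chain of compound 2 at 25 nM, so only a modest drop in this assay is expected. The expected step is a 2.2-fold lower number from compound 1 to compound 3 (0.34 log units; beyond the scatter), and it may not clear the scatter. For compound 3 the estimated value is 3000 nM, with an expected range of 600 nM to 15000 nM.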

Compound 3, half-maximal inhibitory concentration: 8530 nM
Compound 3: the middle estimate sits 2.8-fold (0.45 log units) below what was measured; measured number inside the range.
By their numbers in this assay, from the lowest: compound 2; then compounds 1 and 3 (each within the scatter of the next).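

In this assay, phenyl in place of propyl on a carbonyl carbon gives a 1.3-fold higher number from compound 1 to compound 3 (0.11 log units; within the scatter), so at this position an aromatic ring and a short chain cannot be told apart. Swapping in this larger group also does not bring the number near that of compound 2, at 25 nM. No data at hand bear on the reason for this result. Still open, from the compounds shown here alone, is how the number moves with a chain of intermediate length, such as octyl or dodecyl, and whether a benzyl group or a cyclohexyl ring reads like phenyl.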